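The source may hold more compounds than are shown below. What is called first, only, known or untested is meant among the compounds shown, and "the series" means these compounds.

Compound 1 `O=S(=O)(c1ccccc1)c1nc2ccccc2nc1Nc1ccccc1`, compound 2 `COc1ccc(Nc2nc3ccccc3nc2S(=O)(=O)c2ccccc2)cc1` and compound 3 `COc1cc(Nc2nc3ccccc3nc2S(=O)(=O)c2ccc(C)cc2)cc(OC)c1` were tested in a functional assay on A549 cells (Homo sapiens) for cytotoxicity, read by MTT assay, with a stated time of 72 h; on this read-out higher numbers stand for weaker inhibition and lower numbers for stronger inhibition. Compound 1 gives 26300 nM in this assay, compound 2 gives 11900 nM, and compound 3 gives 8060 nM. Compound 2 carries one change against compound 1 (methoxy in place of hydrogen on an aromatic carbon), and that change made a 2.2-fold lower number from compound 1 to compound 2 (0.34 log units; beyond the scatter). Compound 4 `COc1cc(Nc2nc3ccccc3nc2S(=O)(=O)c2ccc(C)cc2)cc(OC)c1OC` has not yet been measured; it differs from compound 3 by methoxy in place of hydrogen on an aromatic carbon. The surroundings are not identical, since in compound 4 the new group also sits ortho to two methoxy groups, so this is the same kind of change rather than the same change. The difference between the two cores of compound 1 and compound 3 is not broken down here. Resting on the step that the same kind of change gave between compound 1 and compound 2, compound 4 is expected to show a 1.6-fold lower number from compound 3 to compound 4 (0.21 log units; within the scatter) in this assay, placing compound 4 at an estimated 5000 nM, within 2000 nM to 15000 nM.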

Compound 4, half-maximal inhibitory concentration: 5610 nM
Compound 4: the middle estimate sits 1.1-fold (0.05 log units) below what was measured; the range from low to high includes it.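

On the second core, methoxy in place of hydrogen gave a 1.4-fold lower number from compound 3 to compound 4 (0.16 log units; within the scatter) in this assay, so this step alone cannot be told apart from measurement noise. Set beside the earlier step, it does not differ measurably: the same change on two cores in this assay, a 2.2-fold lower number (0.34 log units; beyond the scatter) from compound 1 to compound 2 and a 1.4-fold lower number (0.16 log units; within the scatter) from compound 3 to compound 4, 1.5-fold (0.19 log units) apart, within the scatter of two such steps. This fits the change carrying over between the two cores, but it does not prove that it does: only two pairs are shown, the second step is within the scatter, and in compound 4 the new methoxy sits ortho to two methoxy groups.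

The compounds shown leave open whether another group in that place, such as an amine or a carboxylic acid, would give a clearer step. They also leave open whether the methoxy step would hold in other cell lines.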